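This account rests on a few compounds, and the source may have more. Where it says the series, first, only, none or still open, it means among the compounds named here.

Within the data shown here, compound 2 `COC(=O)c1nc(C2CC2)n(-c2ccc(F)cc2)n1` holds the only number among the values so far: in a functional assay on Jurkat cells (Homo sapiens) for inhibition, read by MTT assay, with a stated time of 72 h (on this read-out lower numbers stand for stronger inhibition of growth and higher numbers for weaker inhibition of growth), compound 2 gives 9420 nM. Compound 1 `COC(=O)c1nc(C(C)C)n(-c2ccc(F)cc2)n1` reaches only a limit of this assay, with > 100000 nM. Among the measured compounds shown here, the single measured step, an at least 10-fold lower number from compound 1 to compound 2 (1.02 log units; beyond the scatter), was large. Compound 3 `COC(=O)c1nc(C2CCCCC2)n(-c2ccc(F)cc2)n1` differs from compound 2 by cyclohexyl in place of cyclopropyl on an aromatic carbon. For the measured compounds named here, that measured step is the only guide and it compares a different pair of groups at the same place, so for this exchange a weakening step is expected, a 4.2-fold higher number from compound 2 to compound 3 (0.63 log units; beyond the scatter). Compound 3 is therefore estimated at 40000 nM in this assay, within a range from 8000 nM to 150000 nM.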

Compound 3, concentration for 50% growth inhibition: > 100000 nM
Compound 3 gave a limit, no number (the forecaster's own chance of this, stated with the estimate: 35%); at least 2.5-fold (0.39 log units) between middle value and limit.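

At this position, on the aromatic carbon between two ring nitrogen atoms, cyclopropyl alone among the three groups shown gives a number in this assay, and cyclohexyl in its place brings an at least 10-fold higher number from compound 2 to compound 3 (1.02 log units; beyond the scatter). The step between compound 1 and compound 3 cannot be read, as both values are limits. Isopropyl in compound 1 and cyclohexyl in compound 3 thus end at the same limit: the limit of > 100000 nM in this assay, at which 2 of the 3 values shown sit.

The compounds shown leave open whether cyclobutyl, an ethyl chain or an amine at this position would give a number, and how a carboxylic acid in place of the methoxycarbonyl group would read.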